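Swapping a Propyl for an Isopentyloxy Group

The source may report more compounds than this note shows. Statements on the series, on what has been measured and on what is new or still open speak of the compounds shown alone.

Compound 1 `CCCCc1ccc(-c2c(C)[nH]c(=O)n2C2CCCCC2)cc1`: 27100 nM
Compound 2 `CCCc1ccc(-c2c(C)[nH]c(=O)n2C2CCCCC2)cc1`: 13900 nM

Both compounds were tested in a functional assay on brain (Rattus norvegicus, strain Wistar) for inhibition; on this read-out lower numbers stand for stronger inhibition and higher numbers for weaker inhibition. Compound 2 shows the lowest of the two numbers, yet the step of a 1.9-fold lower number from compound 1 to compound 2 (0.29 log units; within the scatter) lies within the scatter, so neither compound can be called stronger. Compound 3 `Cc1[nH]c(=O)n(C2CCCCC2)c1-c1ccc(OCCC(C)C)cc1` differs from compound 2 by isopentyloxy in place of propyl on an aromatic carbon. Among the compounds with values here, no measured step bears on this change; the single step seen concerns the chain, not an oxygen-linked group, and stayed within the scatter. Compound 3 is therefore expected to give about 10000 nM in this assay. Its expected range runs from 3000 nM to 40000 nM. This estimate means an expected step of a 1.4-fold lower number from compound 2 to compound 3 (0.14 log units; within the scatter), not clearly beyond the scatter.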

Compound 3, half-maximal inhibitory concentration: 7200 nM
Compound 3: the middle estimate sits 1.4-fold (0.14 log units) above what was measured; the range from low to high includes it.
By their numbers in this assay, from the lowest: compounds 3, 2 and 1 (each within the scatter of the next, the first and the last beyond it).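

On the aromatic carbon para to a large group, an oxygen-linked chain can now be compared with all-carbon chains. Against propyl, the step (a 1.9-fold lower number from compound 2 to compound 3 (0.29 log units; within the scatter)) does not separate the two compounds, but against butyl, the step (a 3.8-fold lower number from compound 1 to compound 3 (0.58 log units; beyond the scatter)) is modest and the first in this set to lie beyond the scatter in this assay. No supporting data explain either step. The compounds shown leave open whether the oxygen or the length of the chain matters more. They also leave open how a methoxy group, an amine or a carboxylic acid would read out on this carbon.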